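The compounds below may be only part of what the source reports. "The series", "measured", "known", "first", "only" and "open" are said of these compounds alone.

In a functional assay on HL-60 cells (Homo sapiens) for cytotoxicity, read by luminescence and CellTiter-Glo, with a stated time of 3 days (on this read-out higher numbers stand for weaker inhibition and lower numbers for stronger inhibition), compound 3 `O=C(Nc1ccccc1)c1cc(F)ccc1O` reads > 10000 nM, a limit of the assay and not a number. Compound 4 `O=C(Nc1cccc(OC(F)(F)F)c1)c1cc(F)ccc1O` differs from it by trifluoromethoxy in place of hydrogen on an aromatic carbon, meta to a large group. Among the measured compounds shown here, two measured steps bear on this, both with a substituent replaced by hydrogen. With trifluoromethyl leaving compound 2 `O=C(Nc1ccc(C(F)(F)F)cc1)c1cc(F)ccc1O`, the step is large: an at least 20-fold higher number from compound 2 to compound 3 (1.30 log units; beyond the scatter). With cyano leaving compound 1 `N#Cc1cccc(NC(=O)c2cc(F)ccc2O)c1`, the floor lies within the scatter: an at least 1.2-fold higher number from compound 1 to compound 3 (0.11 log units; that floor lies within the scatter). A drop beyond the scatter is therefore expected, resting on compound 2 at 490 nM and tempered by compound 1 at 7750 nM. The expected change is an at least 7.6-fold lower number from compound 3 to compound 4 (0.88 log units; beyond the scatter). For compound 4 the estimated value is 1300 nM, with an expected range of 300 nM to 6000 nM.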

Compound 4, half-maximal inhibitory concentration: 730 nM
Estimate against measurement, compound 4: 1.8-fold (0.25 log units) above; the range from low to high includes it.
By their numbers in this assay, from the lowest: compounds 2 and 4 (each within the scatter of the next); then compound 1. At a limit, above all of these: compound 3.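

Trifluoromethoxy, meta to a large group, gives an at least 13-fold lower number from compound 3 to compound 4 (1.13 log units; beyond the scatter) and so shows that a substituent at this position can move the reading beyond the scatter. Cyano on that carbon had left only a floor within the scatter, and exchanging it gives an 11-fold lower number from compound 1 to compound 4 (1.03 log units; beyond the scatter) so the identity of the group counts here, not substitution alone. The reading for compound 3 is a limit of the assay and not a number: the limit of > 10000 nM in this assay, at which 1 of the 4 values shown sits.

Open, going by these compounds, is whether methoxy on this carbon reads like trifluoromethoxy. On these data alone, an amine or a carboxylic acid there also remains untested against this reading.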